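Swapping a para group on compound 1: dimethylamino to bromo

The source may hold more compounds than are shown below. What is called first, only, known or untested is meant among the compounds shown, and "the series" means these compounds.

Compound 1 `CCCSc1nc(N/N=C/c2ccc(N(C)C)cc2)c2nnn(Cc3ccccc3)c2n1` is the starting point. In a functional assay on MGC-803 cells (Homo sapiens) for antiproliferative activity, read by MTT assay, with a stated time of 72 h (a lower number here means a stronger inhibitor, a higher number a weaker inhibitor), compound 1 gives 13100 nM, and this number lies within the usual scatter of both companions: compound 2 `CCCSc1nc(N/N=C(\C)c2ccccc2O)c2nnn(Cc3ccc(F)cc3)c2n1` gives 11000 nM and compound 3 `CCCSc1nc(N/N=C(\C)c2ccccc2O)c2nnn(Cc3ccc(O)cc3)c2n1` gives 7680 nM in this assay. For the measured compounds named here, the one measured step, a 1.4-fold lower number from compound 2 to compound 3 (0.16 log units; within the scatter), stays within the scatter. Compound 4 `CCCSc1nc(N/N=C/c2ccc(Br)cc2)c2nnn(Cc3ccccc3)c2n1` differs from compound 1 by a single change: bromo in place of dimethylamino on an aromatic carbon. Going by the values given here, no measured step exchanges these two groups, and the step from compound 2 to compound 3 alters a different ring and offers no guide. Compound 4 is therefore expected to show no step beyond the scatter, a 1.0-fold lower number from compound 1 to compound 4 (0.00 log units; within the scatter). The estimate for compound 4 in this assay is 13000 nM, with a range from 5000 nM to 35000 nM.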

Compound 4, half-maximal inhibitory concentration: 34900 nM
Estimate against measurement, compound 4: 2.7-fold (0.43 log units) below; the range from low to high includes it.
By their numbers in this assay, from the lowest: compounds 3, 2 and 1 (each within the scatter of the next); then compound 4.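

For the compounds shown here, the exchange of 4-(dimethylamino)phenyl for 4-bromophenyl gives the first step in this assay that lies beyond the scatter (a 2.7-fold higher number from compound 1 to compound 4 (0.43 log units; beyond the scatter)), so a change at this place on the ring registers in the read-out, though only modestly. Going by these compounds alone, the one earlier step, made on a different ring, stayed within the scatter. Nothing measured here accounts for the loss on moving from dimethylamino to bromo.

Going by these compounds, whether a primary amine or a methoxy group at this place would sit nearer compound 1 or compound 4 stays open. So does whether a carboxylic acid would be tolerated there at all.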